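The source may report more compounds than this note shows. Statements on the series, on what has been measured and on what is new or still open speak of the compounds shown alone.

Measured compounds:
compound 1 `COc1cc(Nc2nc3cccc(-c4c(F)cccc4OC)c3o2)cc(OC)c1OC`, with 2600 nM in an assay on BAF cells for inhibition of ribosomal protein S6 kinase alpha-2 (Mus musculus); on this read-out higher numbers stand for weaker inhibition and lower numbers for stronger inhibition
compound 2 `COc1cccc(F)c1-c1cccc2nc(Nc3cccc(S(N)(=O)=O)c3)oc12`, with > 20000 nM in this assay, a limit
compound 3 `COc1cc(Nc2nc3cccc(-c4ccccc4OC(F)(F)F)c3o2)cc(OC)c1OC`, with > 20000 nM in this assay, a limit

Compound 3 stands at the upper limit of this assay: its value of > 20000 nM is not a number but the boundary the assay reports when no inhibition is resolved, and the limit of > 20000 nM in this assay, at which 2 of the 3 values shown sit, shows that two of the three measured compounds sit there. Compound 4 `COc1cc(Nc2nc3cccc(-c4c(F)cccc4OC(C)C)c3o2)cc(OC)c1OC` is not yet measured. It differs from compound 3 in one place: a group of 11 heavy atoms (9 carbon, 1 oxygen, 1 fluorine; one six-membered aromatic ring of carbon only) in place of a group of 11 heavy atoms (7 carbon, 1 oxygen, 3 fluorine; one six-membered aromatic ring of carbon only), on an aromatic carbon. For the measured compounds named here, only one measured step bears on this change. an at least 7.6-fold higher number from compound 1 to compound 3 (0.88 log units; beyond the scatter) went in the losing direction when the 2-fluoro-6-methoxyphenyl of compound 1 was exchanged for the 2-(trifluoromethoxy)phenyl of compound 3. Compound 4 brings back the fluorine-bearing pattern of compound 1, so the reversal of that step is expected, although the larger alkoxy group leaves the size of the gain uncertain. For compound 4 the expected step is an at least 5.0-fold lower number from compound 3 to compound 4 (0.69 log units; beyond the scatter), giving an estimate of 4000 nM, within 1200 nM to 15000 nM.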

Compound 4, half-maximal inhibitory concentration: > 20000 nM
Compound 4: only a limit was reported; the forecaster's own chance of this, stated with the estimate: 25%; at least 5.0-fold (0.69 log units) between middle value and limit.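

The result isolates the alkoxy group. Compound 1 and compound 4 share the fluorine and differ only in isopropyl in place of methyl on the oxygen. In this assay this single exchange gives an at least 7.6-fold higher number from compound 1 to compound 4 (0.88 log units; beyond the scatter), so keeping the fluorine is not enough to retain the inhibition seen with compound 1. The step between compound 3 and compound 4 cannot be read because both values are limits, and compound 1 remains the only one of the shared-core compounds with a resolved number: the limit of > 20000 nM in this assay, at which 3 of the 4 values shown sit.

As far as these compounds go, how compound 3 and compound 4 rank against each other stays open. The compounds shown also leave open whether an ethyl on that oxygen, intermediate between methyl and isopropyl, would keep a measurable value.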